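Compound 3 to compound 4: an aromatic acid in the ester

A few compounds are considered here, and "the series" means these few. Any claim that something is new, unique, unknown or untested is made for them only; others in the source may bear on it.

In a functional assay on HepG2 cells (Homo sapiens) for antiproliferative activity, read by MTT assay, with a stated time of 72 h (a higher number here means a weaker inhibitor, a lower number a stronger inhibitor), compound 1 `O=C(O)CCC(=O)OCCOc1no[n+]([O-])c1S(=O)(=O)c1ccccc1` gives > 10000 nM as a limit of the assay. Among the compounds with values here, compound 2 `O=C(O)CCC(=O)OCCCOc1no[n+]([O-])c1S(=O)(=O)c1ccccc1` gives 6400 nM and is the only compound here with a number. Compound 3 `O=C(O)CCCC(=O)OCCCOc1no[n+]([O-])c1S(=O)(=O)c1ccccc1` gives > 10000 nM as a limit as well. Compound 4 `O=C(O)c1ccccc1C(=O)OCCCOc1no[n+]([O-])c1S(=O)(=O)c1ccccc1` differs from compound 3 thus: 2-carboxyphenyl in place of 3-carboxypropyl on a carbonyl carbon with 2-carboxyphenyl in place of 3-carboxypropyl on a carbonyl carbon. Within the data shown here, two measured steps bear on it, an at least 1.5-fold lower number from compound 1 to compound 2 (0.19 log units; that floor lies within the scatter) and, on the same acid chain, an at least 1.5-fold higher number from compound 2 to compound 3 (0.19 log units; that floor lies within the scatter) and both floors lie within the scatter. No aromatic group has a measured value at this place, so no step beyond the scatter is expected. The estimated step is an at least 1.2-fold lower number from compound 3 to compound 4 (0.09 log units; that floor lies within the scatter) in this assay with no firm direction expected. Compound 4 is expected at 8000 nM with an estimated range from 2500 nM to 25000 nM for now.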

Compound 4, half-maximal inhibitory concentration: > 10000 nM
Compound 4: only a limit was reported (the forecaster's own chance of this, stated with the estimate: 45%); middle value at least 1.2-fold (0.09 log units) away from the limit.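

Within the data shown here, compound 4 puts the first aromatic group on this carbonyl carbon, and in this assay compound 4 gives > 10000 nM, which is a limit of the assay. Among these compounds, the one readable comparison, with 2-carboxyethyl as the group replaced, is an at least 1.5-fold higher number from compound 2 to compound 4 (0.19 log units; that floor lies within the scatter), so 2-carboxyphenyl shows no gain here. The change from 3-carboxypropyl to 2-carboxyphenyl cannot be read, because compound 3 and compound 4 both stand at a limit: the limit of > 10000 nM in this assay, at which 3 of the 4 values shown sit.

Still open, on these data alone, is how the 2-carboxyphenyl ester ranks against the chain esters. Also open, as far as these compounds go, is whether a plain phenyl group, or an amine in place of the carboxylic acid, would give a readable number.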